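Trifluoromethyl in place of fluoro on an aromatic carbon

A few compounds are considered here, and "the series" means these few. Any claim that something is new, unique, unknown or untested is made for them only; others in the source may bear on it.

In a functional assay on MCF7 cells (Homo sapiens) for inhibition, read by MTT assay, with a stated time of 72 h (a lower number here means a stronger inhibitor, a higher number a weaker inhibitor), compound 1 `COc1cc(NC(C)CCCNC(=O)NNC(=O)Nc2ccc(F)cc2)c2ncccc2c1` gives 310 nM, while compound 2 `COc1cc(NC(C)CCCNC(=O)Nc2ccc(F)cc2)c2ncccc2c1` gives 26000 nM, the higher of the two numbers and so the weaker inhibitor. Compound 3 `COc1cc(NC(C)CCCNC(=O)Nc2ccc(C(F)(F)F)cc2)c2ncccc2c1` has not yet been measured. It departs from compound 2 at one place: trifluoromethyl in place of fluoro on an aromatic carbon. In words, trifluoromethyl stands in place of fluoro on an aromatic carbon. Among the measured compounds shown here, the only measured step, an 84-fold higher number from compound 1 to compound 2 (1.92 log units; beyond the scatter), is large, but it concerns a different place in the structure. For the measured compounds named here, no measured pair changes this fluoro group, so that step sets no size for the new one. A small step towards a lower number is expected, with no clear move beyond the scatter. The estimated step is a 1.7-fold lower number from compound 2 to compound 3 (0.24 log units; within the scatter). Starting from compound 2 at 26000 nM, the expected value for compound 3 is 15000 nM, with an estimated range of 5000 nM to 50000 nM.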

Compound 3, half-maximal inhibitory concentration: 1900 nM
For compound 3 the middle estimate is 7.9-fold (0.90 log units) above the measured one; the measured number lies below the stated range.
By their numbers in this assay, from the lowest: compound 1; then compound 3; then compound 2.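

In this assay, among the compounds shown here, this position on the aromatic ring, para to a large group, proves sensitive: trifluoromethyl in place of fluoro gives a 14-fold lower number from compound 2 to compound 3 (1.14 log units; beyond the scatter), whereas the earlier compounds differed only in the group on the amide-type nitrogen. The change does not close the whole gap to compound 1, since 4-(trifluoromethyl)phenyl in place of ((4-fluorophenyl)carbamoyl)amino still leaves a 6.1-fold higher number from compound 1 to compound 3 (0.79 log units; beyond the scatter) on that nitrogen. Nothing available accounts for the size of the fall on going from fluoro to trifluoromethyl.

The compounds shown leave open whether an amine, a carboxylic acid or a nitrile on this aromatic carbon would lower the number further. They also leave open whether trifluoromethyl in place of fluoro would give a step of similar size in compound 1.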